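Swapping Chloro for Dimethylamino in a Cytotoxicity Series

The source may hold more compounds than are shown below. What is called first, only, known or untested is meant among the compounds shown, and "the series" means these compounds.

Measured compounds:
compound 1 `CC(=O)N1N=C(c2ccco2)CC1c1ccc(Br)cc1`: 47800 nM
compound 2 `CC(=O)N1N=C(c2ccco2)CC1c1ccc(Cl)cc1`: 38900 nM

In a functional assay on IMR-32 cells (Homo sapiens) for cytotoxicity, read by sulforhodamine B assay, with a stated time of 48 h (on this read-out lower numbers stand for stronger inhibition and higher numbers for weaker inhibition), compound 1 gives 47800 nM and compound 2 gives 38900 nM. Within the data shown here, the only measured step, a 1.2-fold lower number from compound 1 to compound 2 (0.09 log units; within the scatter), exchanges one halogen for another, and the two numbers sit within the scatter of each other, so compound 2 cannot be called different from compound 1 on this read-out.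

Compound 3 `CC(=O)N1N=C(c2ccco2)CC1c1ccc(N(C)C)cc1` has not been measured. It differs from compound 2 by dimethylamino in place of chloro on an aromatic carbon. No measured step exchanges a halogen for a dimethylamino group, so the one step shown, from compound 1 to compound 2, bears on this change only loosely; it was within the scatter. On that basis no step beyond the scatter is expected in this assay, and the estimate for compound 3 is 40000 nM, with a range from 12000 nM to 130000 nM, meaning an expected step of a 1.0-fold higher number from compound 2 to compound 3 (0.01 log units; within the scatter).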

Compound 3, half-maximal inhibitory concentration: 16100 nM
For compound 3 the middle estimate is 2.5-fold (0.40 log units) above the measured one, within the range that was stated.
By their numbers in this assay, from the lowest: compound 3; then compounds 2 and 1 (each within the scatter of the next).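

Until now this aromatic carbon had carried only halogens, and exchanging one for the other gave no step beyond the scatter. In this assay, dimethylamino in place of chloro gives a 2.4-fold lower number from compound 2 to compound 3 (0.38 log units; beyond the scatter) and dimethylamino in place of bromo gives a 3.0-fold lower number from compound 1 to compound 3 (0.47 log units; beyond the scatter) as its counterpart, so the group at this carbon can change the number, though only modestly. Compound 3, with its three heavy atoms and one hydrogen-bond acceptor where a single halogen atom stood, therefore shows the strongest inhibition of the three, but no measurement here explains the change.

Going by these compounds, whether this step belongs to dimethylamino specifically or would also appear with a smaller amine, such as methylamino, remains open. So does whether a methoxy group or a larger pyrrolidine ring at this carbon would lower the number further.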